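From Oxolanyl to Methoxypiperidinyl on the Carbonyl Carbon

The compounds below may be only part of what the source reports. "The series", "measured", "known", "first", "only" and "open" are said of these compounds alone.

Compound 1 `O=C([C@H]1CC2CCC1C2)N1CC(c2nc(-c3cccc(F)c3)no2)C1`: 72 nM
Compound 2 `O=C(C1CCCO1)N1CC(c2nc(-c3cccc(Cl)c3)no2)C1`: > 10000 nM
Compound 3 `O=C([C@@H]1CC2CCC1C2)N1CC(c2nc(-c3ccccc3)no2)C1`: 400 nM

Three compounds share a core and were tested in an assay on HEK293 cells for positive allosteric modulation of metabotropic glutamate receptor 5 (Homo sapiens), read by FLIPR; on this read-out higher numbers stand for an effect only at larger amounts of compound and lower numbers for an effect already at smaller amounts. Compound 1 gives 72 nM and compound 3 gives 400 nM in this assay, both as numbers. Compound 2 stands apart: its result in this assay is not a number but a limit, (the limit of > 10000 nM in this assay, at which 1 of the 3 values shown sits), so all that is known is that any effect would need more compound than the assay reaches.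

Compound 4 `COC1CCCN(C(=O)N2CC(c3nc(-c4cccc(Cl)c4)no3)C2)C1` has not yet been measured in this assay. It differs from compound 2 in one place (3-methoxypiperidin-1-yl in place of oxolan-2-yl on a carbonyl carbon). Among the measured compounds shown here, no measured pair shows what such a change does, so the size and direction of the step from compound 2 to compound 4 are open. Because compound 2 sits at the limit of > 10000 nM in this assay, at which 1 of the 3 values shown sits, only a move toward an effect at smaller amounts could be seen at all; the step is expected to be an at least 1.6-fold lower number from compound 2 to compound 4 (0.22 log units; that floor lies within the scatter), and a second limit remains quite possible. Compound 4 is estimated at 6000 nM, most likely between 1000 nM and 30000 nM.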

Compound 4, half-maximal effective concentration: > 10000 nM
Compound 4: no number, only a limit (the forecaster's own chance of this, stated with the estimate: 45%); middle value at least 1.6-fold (0.22 log units) away from the limit.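

Among the compounds shown here, compound 2 and compound 4 each end at a limit in this assay and not at a number, so no step between them can be read: the limit of > 10000 nM in this assay, at which 2 of the 4 values shown sit. The compounds shown leave open whether 3-methoxypiperidin-1-yl in place of oxolan-2-yl on a carbonyl carbon changes the effect at all.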